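Adding a methylpiperazine to a benzothiazole anilide

This account rests on a few compounds, and the source may have more. Where it says the series, first, only, none or still open, it means among the compounds named here.

Three anilides built on a shared core were measured in an ADME assay for permeability, using PAMPA, at pH 7.4; a lower number here means that the compound crosses the layer more slowly, a higher number that the compound crosses the layer faster. Compound 1 `O=C(Nc1cc(-c2nc3ccccc3s2)ccc1Cl)c1cc([N+](=O)[O-])ccc1Cl` gives "below limit of detection" (no number reported) in this assay, so no number is reported for it. Compound 2 `COc1ccc(-c2nc3ccccc3s2)cc1NC(=O)c1cc([N+](=O)[O-])ccc1Cl` likewise gives "below limit of detection" (no number reported) in this assay, again without a number. Compound 3 `O=C(Nc1cccc(-c2nc3ccccc3s2)c1)c1cc([N+](=O)[O-])ccc1Cl`, which carries no substituent on the aniline ring beside the benzothiazole, gives 12 10^-6 cm/s in this assay. So compound 2 stands at the bottom of what the assay can report, together with compound 1, while compound 3 is the only one of the three with a number.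

Compound 4 `COc1ccc(-c2nc3ccccc3s2)cc1NC(=O)c1cc([N+](=O)[O-])c(N2CCN(C)CC2)cc1Cl` differs from compound 2 in one place: 4-methylpiperazin-1-yl in place of hydrogen on an aromatic carbon. Among the measured compounds shown here, no pair of measured compounds differing in just this way is available, so the size of this step cannot be read from the data. Compound 2 itself gives no number, so any movement upward would have to lift compound 4 into the measurable range; a change beyond the scatter cannot be ruled out in either direction. On balance compound 4 is expected to give about 1.5 10^-6 cm/s in this assay, with a plausible range from 0.3 10^-6 cm/s to 8 10^-6 cm/s, and a real chance that no number is reported again.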

Compound 4, apparent permeability: 676 10^-6 cm/s
For compound 4 the middle estimate is 450-fold (2.65 log units) below the measured one, outside the stated range (above it).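

Among the compounds shown here, compound 2 carries no number in this assay, and no step to compound 4 can therefore be read from this pair. No measurement shown bears on why compound 4 gives the value it does. The compounds shown leave open how large a change 4-methylpiperazin-1-yl in place of hydrogen would make on a compound with a numerical starting value, such as compound 3.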